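This account rests on a few compounds, and the source may have more. Where it says the series, first, only, none or still open, it means among the compounds named here.

In a functional assay on A-375 cells (Homo sapiens) for activation, with a stated time of 3 days (on this read-out higher numbers stand for an effect only at larger amounts of compound and lower numbers for an effect already at smaller amounts), compound 2 `O=C(Nc1ccc(-c2cscn2)cc1)C1CCCN(Cc2cccc(F)c2)C1` gives 5000 nM as the only true number shown. Compound 1 `O=C(NC1CCCN(Cc2ccc(F)c(F)c2)C1)c1ccc(-c2cscn2)cc1` reads > 20000 nM and that is a limit of the assay, not a number. Compound 3 `O=C(Nc1ccc(-c2cscn2)cc1)C1CCCN(Cc2cccc(OC(F)(F)F)c2)C1` reads > 20000 nM and that too is a limit, not a number. Compound 2 therefore stands alone on the scale, with no second number to set it against.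

Compound 4 `O=C(Nc1ccc(-c2cscn2)cc1)C1CCCN(Cc2cccnc2)C1` has not yet been measured. Its difference from compound 2 is pyridin-3-yl in place of 3-fluorophenyl on a saturated chain carbon bound to an amine nitrogen in a ring in one swap: pyridin-3-yl in place of 3-fluorophenyl on a saturated chain carbon bound to an amine nitrogen in a ring.

Among the compounds with values here, the one measured step that alters the 3-fluorobenzyl group is an at least 4.0-fold higher number from compound 2 to compound 3 (0.60 log units; beyond the scatter) and it swaps only the fluoro, so it is a loose guide, but it leads to the expectation of a higher number for compound 4 as well. The estimated step is a 2.0-fold higher number from compound 2 to compound 4 (0.30 log units; within the scatter) and it is expected to be modest. The measurements also show the limit of > 20000 nM in this assay, at which 2 of the 3 values shown sit, and compound 4 may likewise report only that limit. For compound 4 the estimate is 10000 nM as the expected value, with a range from 3000 nM to 20000 nM expected to hold most repeat measurements.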

Compound 4, half-maximal effective concentration: > 20000 nM
Compound 4: only a limit was reported (the forecaster's own chance of this, stated with the estimate: 45%); at least 2.0-fold (0.30 log units) between middle value and limit.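

Replacing the 3-fluorophenyl with pyridin-3-yl on a saturated chain carbon bound to an amine nitrogen in a ring gives an at least 4.0-fold higher number from compound 2 to compound 4 (0.60 log units; beyond the scatter) in this assay. Within the data shown here, until now, the only measured change to this group was a swap of its fluoro, whereas this result shows that exchanging a ring carbon for nitrogen and losing the fluoro also moves the read-out beyond the scatter, in the same direction. Compound 4 reads > 20000 nM, which is a limit and not a number, so the true size of the step remains unknown, and the scale offers little room to resolve such changes in this series: the limit of > 20000 nM in this assay, at which 3 of the 4 values shown sit.

Among these compounds, with both compound 3 and compound 4 at the limit, their order relative to each other cannot be read, and the 3-fluorophenyl of compound 2 remains the only group at this place with a true number. As far as these compounds go, how a plain phenyl, a 3-chlorophenyl or a phenyl carrying a methoxy group would read here stays open, as does whether any group at this place could give a lower number than compound 2.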